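This account rests on a few compounds, and the source may have more. Where it says the series, first, only, none or still open, it means among the compounds named here.

Measured so far:
Compound 1 `CN(C(=S)SCc1ccc(C(=O)Nc2ccccc2N)cc1)c1cccnc1` — 16%
Compound 2 `Nc1ccccc1NC(=O)c1ccc(CSC(=S)N2CCc3cc(Cl)ccc32)cc1` — 40.1%
Compound 3 `CC1CCCCN1C(=S)SCc1ccc(C(=O)Nc2ccccc2N)cc1` — 45.5%

All three were tested in a functional assay on HeLa cells (Homo sapiens) for antiproliferative activity, read by CCK-8 assay, with a stated time of 72 h, tested at 2 uM; a lower number here means a weaker effect, a higher number a stronger effect of the compound at the concentration tested. Compound 3 gives the highest number of the three; its step to compound 2, a number 5.4 percentage points higher from compound 2 to compound 3 (within the scatter), is within the scatter, so the two cannot be ordered, while its gap to compound 1, a number 29.5 percentage points higher from compound 1 to compound 3 (beyond the scatter), is beyond the scatter. The other step from compound 1, a number 24.1 percentage points higher from compound 1 to compound 2 (beyond the scatter), is of similar size.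

Compound 4 `CC1CCN(C(=S)SCc2ccc(C(=O)Nc3ccccc3N)cc2)CC1` is not yet measured. The change from compound 3 is 4-methylpiperidin-1-yl in place of 2-methylpiperidin-1-yl on a thiocarbonyl carbon. Among the measured compounds shown here, no measured step moves a methyl around the same piperidine ring, so none bears on this change directly. The measured steps only show that replacing the methyl(pyridin-3-yl)amino group with a cyclic amine raises the number modestly, and that swapping one cyclic amine for another (a number 5.4 percentage points higher from compound 2 to compound 3 (within the scatter)) stays within the scatter. For compound 4 a step of a number 3.5 percentage points lower from compound 3 to compound 4 (within the scatter) is therefore expected, nothing beyond the scatter. Compound 4 is estimated at 42%, with a range from 25% to 58%.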

Compound 4, a percentage reported as inhibition, at one concentration (the size of the read-out at that concentration, not a potency): 46.8%
Compound 4: middle estimate off by 4.8 percentage points, on the low side, and the stated range covers the measured number.
By their numbers in this assay, from the lowest: compound 1; then compounds 2, 3 and 4 (each within the scatter of the next).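

In this assay, moving the methyl around the piperidine ring on the thiocarbonyl carbon gives a number 1.3 percentage points higher from compound 3 to compound 4 (within the scatter), so 4-methylpiperidin-1-yl and 2-methylpiperidin-1-yl cannot be told apart at the concentration tested. The data also give a number 6.7 percentage points higher from compound 2 to compound 4 (within the scatter) and a number 30.8 percentage points higher from compound 1 to compound 4 (beyond the scatter), which places the three cyclic amines together, with the methyl(pyridin-3-yl)amino compound alone apart from them. No evidence on the reason for this grouping is available.

As far as these compounds go, it remains open whether an unsubstituted piperidine, a morpholine or a piperazine with a free ring amine would stay with this group. A diethylamino group would help show whether the ring itself matters or whether the gap is specific to methyl(pyridin-3-yl)amino, and a single-concentration read-out gives no potencies for any of these compounds.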